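This account rests on a few compounds, and the source may have more. Where it says the series, first, only, none or still open, it means among the compounds named here.

- compound 1 `COc1cc2oc(-c3cccc(NC(=O)c4cccc(Br)c4)c3)cc(=O)c2c(OC)c1OC`: 10900 nM
- compound 2 `COc1cc2oc(-c3cccc(NC(=O)c4cccc(C#N)c4)c3)cc(=O)c2c(OC)c1OC`: 11900 nM

Within the data shown here, in a functional assay on HepG2 cells (Homo sapiens) for inhibition, read by MTT assay (a higher number here means a weaker inhibitor of growth, a lower number a stronger inhibitor of growth), compound 1 stands level with compound 2, its only neighbour on the scale. The a 1.1-fold higher number from compound 1 to compound 2 (0.04 log units; within the scatter) shows that cyano in place of bromo on an aromatic carbon left the number within the scatter.

Compound 3 `COc1cc2oc(-c3cccc(NC(=O)c4cccc(Br)c4)c3)cc(=O)c2c(O)c1OC` has not yet been measured. It differs from compound 1 as follows: hydrogen in place of methyl on an oxygen on an aromatic ring. This is hydrogen in place of methyl on an oxygen on an aromatic ring, or methoxy to hydroxy.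

Among the measured compounds shown here, the one measured step concerns a different change, so it bears on this one only indirectly, and no measured pair tests methoxy to hydroxy. No step beyond the scatter is therefore expected, and no direction can be favoured with confidence.

The expected change is a 1.2-fold lower number from compound 1 to compound 3 (0.08 log units; within the scatter). For compound 3 the estimated value is 9000 nM, with an expected range from 3500 nM to 25000 nM.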

Compound 3, concentration for 50% growth inhibition: 44800 nM
For compound 3 the middle estimate is 5.0-fold (0.70 log units) below the measured one, outside the stated range (above it).
By their numbers in this assay, from the lowest: compounds 1 and 2 (each within the scatter of the next); then compound 3.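

In this assay, among these compounds, the core proved sensitive to a change that the earlier compounds did not probe: methoxy to hydroxy gave a 4.1-fold higher number from compound 1 to compound 3 (0.61 log units; beyond the scatter), so compound 3 is a weaker inhibitor of growth than compound 1. Until then, the only measured step, a 1.1-fold higher number from compound 1 to compound 2 (0.04 log units; within the scatter), lay on the other side of the amide and stayed within the scatter, so this is the first step shown to move the number beyond it. Nothing available explains why removing this methyl has that effect.

The compounds shown leave open whether a longer chain such as ethyl on this oxygen, or an amine in place of the methoxy, would give a similar number. They also leave open whether methoxy to hydroxy would give a step of similar size with the nitrile of compound 2 in place of the bromo.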